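The source may report more compounds than this note shows. Statements on the series, on what has been measured and on what is new or still open speak of the compounds shown alone.

Three compounds share one core and differ only in the group on the carbonyl carbon. Compound 1 `Cc1ccc(C(=O)N2N=C(c3cc4ccccc4oc3=O)CC2c2ccccc2)cc1` gives 13200 nM in a functional assay on PC-3 cells (Homo sapiens) for cytotoxicity, read by MTT assay, with a stated time of 48 h; a lower number here means a stronger inhibitor, a higher number a weaker inhibitor. Compound 2 `O=C(c1ccccc1Cl)N1N=C(c2cc3ccccc3oc2=O)CC1c1ccccc1` gives 6370 nM, and compound 3 `O=C(CN1CCCC1)N1N=C(c2cc3ccccc3oc2=O)CC1c1ccccc1` gives 50200 nM. Compound 3 thus stands at the highest number of the three: the step of a 3.8-fold higher number from compound 1 to compound 3 (0.58 log units; beyond the scatter) and the step of a 7.9-fold higher number from compound 2 to compound 3 (0.90 log units; beyond the scatter) both run upward to it, while the step of a 2.1-fold lower number from compound 1 to compound 2 (0.32 log units; beyond the scatter) runs between the two aryl members only.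

Compound 4 `CC1CCCCN1CC(=O)N1N=C(c2cc3ccccc3oc2=O)CC1c1ccccc1` is not yet measured. It differs from compound 3 by 2-methylpiperidin-1-yl in place of pyrrolidin-1-yl on a saturated chain carbon bound to a carbonyl carbon. For the measured compounds named here, no measured step exchanges one saturated amine ring for another; the measured steps concern only the exchange of the whole (pyrrolidin-1-yl)methyl group for an aryl group. They show that the (pyrrolidin-1-yl)methyl arrangement sits at the weak end, and the change to compound 4 keeps that arrangement. Compound 4 is therefore expected to remain near compound 3, with an estimated step of a 1.1-fold lower number from compound 3 to compound 4 (0.05 log units; within the scatter) that does not clearly exceed the scatter. The estimate for compound 4 is 45000 nM, within a range of 18000 nM to 110000 nM.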

Compound 4, half-maximal inhibitory concentration: 36300 nM
Compound 4: the middle estimate sits 1.2-fold (0.09 log units) above what was measured; low and high end bracket the measured number.
By their numbers in this assay, from the lowest: compound 2; then compound 1; then compounds 4 and 3 (each within the scatter of the next).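

Exchanging pyrrolidin-1-yl for 2-methylpiperidin-1-yl on a saturated chain carbon bound to a carbonyl carbon gives a 1.4-fold lower number from compound 3 to compound 4 (0.14 log units; within the scatter) in this assay, so this change of amine ring, with its added methyl, does not move the number beyond the scatter. Both aryl members stay apart from the new compound, with a 5.7-fold higher number from compound 2 to compound 4 (0.76 log units; beyond the scatter) and a 2.8-fold higher number from compound 1 to compound 4 (0.44 log units; beyond the scatter), so the higher numbers now hold for two saturated amine rings and not for pyrrolidin-1-yl alone. Nothing available here bears on the reason for this.

The compounds shown leave open whether an open-chain amine such as diethylamino, or a morpholine ring, would stay in the same range at this place. They also leave open what a longer chain carrying the amine ring would do, and whether ring size and methyl group count separately, as compound 4 carries both changes at once.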